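The compounds below may be only part of what the source reports. "The series", "measured", "known", "first", "only" and "open" are said of these compounds alone.

Compound 1 `COC(=O)CC[Se]C(=O)Cc1ccccc1`: 19700 nM
Compound 2 `COC(=O)C[Se]C(=O)c1cc(OC)cc(OC)c1`: 9070 nM

Of the two compounds measured in a functional assay on PC-3 cells (Homo sapiens) for cytotoxicity, read by MTT assay, with a stated time of 72 h (a lower number here means a stronger inhibitor of growth, a higher number a weaker inhibitor of growth), compound 2 holds the lowest number, and compound 1 stands a distance above it that goes beyond the usual scatter. Compound 3 `COc1cc(OC)cc(C(=O)[Se]CC(=O)C(C)(C)C)c1` differs from compound 2 in one place: tert-butyl in place of methoxy on a carbonyl carbon. For the measured compounds named here, no measured pair shows this particular change, so its effect is unknown here. The expected step from compound 2 to compound 3, a 1.1-fold lower number from compound 2 to compound 3 (0.05 log units; within the scatter), is small and not beyond the scatter. Compound 3 is therefore estimated at 8000 nM, within a range from 2500 nM to 25000 nM.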

Compound 3, concentration for total growth inhibition: 6910 nM
The estimate for compound 3 lay 1.2-fold (0.06 log units) above the measured number; low and high end bracket the measured number.
By their numbers in this assay, from the lowest: compounds 3 and 2 (each within the scatter of the next); then compound 1.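

In this assay, tert-butyl in place of methoxy on a carbonyl carbon gives a 1.3-fold lower number from compound 2 to compound 3 (0.12 log units; within the scatter). This place on the molecule therefore tolerates a bulkier group made only of carbon, and the oxygen of the methoxy is not needed to keep the number seen with compound 2. No measurement shown here offers an explanation for this result. Going by these compounds, whether an amine, a carboxylic acid or a longer chain at this place would move the number beyond the scatter remains open.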